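Swapping sec-butyl for isobutyl on an inactive compound

The source may report more compounds than this note shows. Statements on the series, on what has been measured and on what is new or still open speak of the compounds shown alone.

Compound 1 (`CCC(C)NC(=C\C(=O)/C=C/c1ccc(O)c(OC)c1)/C=C/c1ccc(O)c(OC)c1`) gives > 25000 nM as a limit
Compound 2 (`CCC(C)NC(=C\C(=O)/C=C/c1ccc(O)cc1)/C=C/c1ccc(O)cc1`) gives > 25000 nM as a limit

In an ADME assay on EA.hy 926 cells (Homo sapiens) for inhibition, read by sulforhodamine B assay, with a stated time of 72 h (on this read-out higher numbers stand for weaker inhibition and lower numbers for stronger inhibition), compound 1 stands at > 25000 nM and this is a limit, not a number. Compound 2 gives > 25000 nM and this too is only a limit. For the measured compounds named here, the two compounds therefore offer no number to compare, and the record so far reads (the limit of > 25000 nM in this assay, at which 2 of the 2 values shown sit) with no measured step to go by.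

Compound 3 (`COc1cc(/C=C/C(=O)/C=C(/C=C/c2ccc(O)c(OC)c2)NCC(C)C)ccc1O`) has not yet been measured. It keeps the core of compound 1 and carries isobutyl in place of sec-butyl on an amine nitrogen so the two have the same atoms, joined differently. No step beyond the usual scatter is expected in this assay and the expected step is a number no higher from compound 1 to compound 3 (the limit leaves the size open) in this read-out. That expectation rests on the limit of compound 1 at > 25000 nM in this read-out. Compound 3 is estimated at 25000 nM within an expected range from 12000 nM to 50000 nM in this read-out, and a report of only a limit is the likely outcome.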

Compound 3, half-maximal inhibitory concentration: > 25000 nM
Compound 3: no number, only a limit; the forecaster's own chance of this, stated with the estimate: 80%; the middle value sits exactly at the limit.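

In this assay compound 3 gives > 25000 nM, which is a limit and not a number. Compound 1 also stands only at a limit, so no step can be read between compound 1 and compound 3. The record now reads: the limit of > 25000 nM in this assay, at which 3 of the 3 values shown sit.

The compounds shown leave open how strongly any of them inhibits and whether isobutyl and sec-butyl differ at all on this read-out.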